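This account rests on a few compounds, and the source may have more. Where it says the series, first, only, none or still open, it means among the compounds named here.

Measured so far:
compound 1 `CCc1ccc(-c2ccc(NC3=CC(=O)c4ncncc4C3=O)cc2)cc1` – 1200 nM
compound 2 `Cc1ccc(-c2ccc(NC3=CC(=O)c4ncncc4C3=O)cc2F)cc1` – 4800 nM
compound 3 `CC(=O)c1cccc(NC2=CC(=O)c3ncncc3C2=O)c1` – 900 nM

In a functional assay on PANC-1 cells (Homo sapiens) for cytotoxicity, read by MTT assay, with a stated time of 72 h (a lower number here means a stronger inhibitor, a higher number a weaker inhibitor), compound 1 gives 1200 nM, the second highest of the three numbers. Compound 3 stands nearest, and its value lies within the scatter of that of compound 1, so the two cannot be told apart. Compound 2 stands furthest, with a higher number that lies beyond the scatter.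

Compound 4 `CCOC(=O)c1ccc(NC2=CC(=O)c3ncncc3C2=O)cc1` has not been measured in this assay. It differs from compound 1 in one place: ethoxycarbonyl in place of 4-ethylphenyl on an aromatic carbon. The ethoxycarbonyl replaces the 4-ethylphenyl on an aromatic carbon of the shared core.

For the measured compounds named here, no step between measured compounds covers a change of this kind. The change is expected to give a small step toward a higher number, at most near the edge of the scatter. Compound 4 is therefore expected to give about 1600 nM in this assay, within 500 nM to 5000 nM, which means an expected step of a 1.3-fold higher number from compound 1 to compound 4 (0.12 log units; within the scatter).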

Compound 4, half-maximal inhibitory concentration: 1600 nM
The estimate for compound 4 equals the measured number at the digits printed; the measured number falls inside the stated range.
By their numbers in this assay, from the lowest: compounds 3, 1 and 4 (each within the scatter of the next); then compound 2.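

In this assay the exchange of 4-ethylphenyl for ethoxycarbonyl on an aromatic carbon gives a 1.3-fold higher number from compound 1 to compound 4 (0.12 log units; within the scatter), so the two compounds cannot be told apart. For the compounds shown here, at this position, then, a group with no ring and with hydrogen-bond acceptors reads the same as one holding a six-membered aromatic ring of carbon only, which the earlier compounds, none differing in one place, could not show. No measured evidence bears on this result. Going by these compounds, whether a carboxylic acid, an amide or an amine here would read the same stays open, as does a longer ester chain.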